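This account rests on a few compounds, and the source may have more. Where it says the series, first, only, none or still open, it means among the compounds named here.

Compound 1 `COc1ccc(/C=C\c2cc(OC)c(OC)c(OC)c2)cc1B(O)O` gives 13 nM
Compound 2 `COc1cc(/C=C\c2cccc(B(O)O)c2)cc(OC)c1` gives 2000 nM

In a functional assay on 1-87 cells (Homo sapiens) for cytotoxicity (a lower number here means a stronger inhibitor, a higher number a weaker inhibitor), compound 2 stands highest of the two, beyond the scatter from compound 1. Compound 3 `COc1cc(/C=C\c2ccc(OC)c(B(O)O)c2)cc(OC)c1` differs from compound 2 by methoxy in place of hydrogen on an aromatic carbon, ortho to a group of 3 heavy atoms and para to a large group (methoxy in place of hydrogen on an aromatic carbon). Among the measured compounds shown here, no measured pair isolates this change. Compound 1 also carries such a methoxy and gives 13 nM, so a sizeable fall beyond the scatter is expected, though probably not to the level of compound 1. The expected step is a 5.7-fold lower number from compound 2 to compound 3 (0.76 log units; beyond the scatter). For compound 3 the estimated value is 350 nM, with an expected range from 70 nM to 1800 nM.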

Compound 3, half-maximal inhibitory concentration: 28 nM
For compound 3 the middle estimate is 13-fold (1.10 log units) above the measured one, outside the stated range (below it).
By their numbers in this assay, from the lowest: compound 1; then compound 3; then compound 2.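

In this assay, among the compounds shown here, the methoxy in place of hydrogen, ortho to a group of 3 heavy atoms and para to a large group, gives a 71-fold lower number from compound 2 to compound 3 (1.85 log units; beyond the scatter) and so carries most of the gap between the earlier compounds. The remaining methoxy difference gives a 2.2-fold higher number from compound 1 to compound 3 (0.33 log units; beyond the scatter) and is a much smaller step, though beyond the scatter. Nothing available gives a reason for either step. Going by these compounds, whether an ethoxy group, an amine or a fluorine atom in the same place would keep this gain remains open.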